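Swapping chloro for methyl: compound 3 to compound 4

The compounds below may be only part of what the source reports. "The series", "measured", "known", "first", "only" and "open" are said of these compounds alone.

Measured in a functional assay on cells (leukaemia cell line, Homo sapiens) for inhibition, read by sulforhodamine B assay, with a stated time of 48 h; a higher number here means a weaker inhibitor of growth, a lower number a stronger inhibitor of growth:
- Compound 1 `O=S(=O)(Nc1ccc(Cl)cc1Cl)c1ccc(-c2cnc(C3CC3)o2)cc1`: 481 nM
- Compound 2 `O=S(=O)(Nc1cccc(Cl)c1)c1ccc(-c2cnc(C3CC3)o2)cc1`: 477 nM
- Compound 3 `Cc1cc(NS(=O)(=O)c2ccc(-c3cnc(C4CC4)o3)cc2)ccc1Cl`: 216 nM

Compound 3 has the lowest number of the three, which makes it the strongest inhibitor of growth so far. Compound 4 `Cc1ccc(NS(=O)(=O)c2ccc(-c3cnc(C4CC4)o3)cc2)cc1C` carries methyl in place of chloro on an aromatic carbon, turning 4-chloro-3-methylphenyl into 3,4-dimethylphenyl.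

Among the measured compounds shown here, no measured step makes this exact swap. The closest evidence comes from other changes to the group on the sulfonamide nitrogen. Two were modest, a 2.2-fold lower number from compound 1 to compound 3 (0.35 log units; beyond the scatter) and a 2.2-fold lower number from compound 2 to compound 3 (0.34 log units; beyond the scatter), and one was a 1.0-fold lower number from compound 1 to compound 2 (0.00 log units; within the scatter). A small rise in the number is therefore expected in this assay, perhaps no larger than the scatter. The estimated step is a 1.3-fold higher number from compound 3 to compound 4 (0.11 log units; within the scatter). The estimate for compound 4 is 280 nM, with an expected range of 120 nM to 620 nM.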

Compound 4, concentration for 50% growth inhibition: 420 nM
Beside the measured number, compound 4's estimate is 1.5-fold (0.18 log units) below it, within the range that was stated.
By their numbers in this assay, from the lowest: compounds 3, 4, 2 and 1 (each within the scatter of the next, the first and the last beyond it).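

In this assay the swap of chloro for methyl on this aromatic carbon gives a 1.9-fold higher number from compound 3 to compound 4 (0.29 log units; within the scatter) and so does not separate the two groups. With no chlorine left on the ring, the other comparisons read a 1.1-fold lower number from compound 2 to compound 4 (0.06 log units; within the scatter) and a 1.1-fold lower number from compound 1 to compound 4 (0.06 log units; within the scatter) and both stay within the scatter, so growth inhibition in this range does not depend on chlorine on this ring.

Nothing measured here explains these steps. Going by these compounds, whether a methoxy group, an amine or a longer chain at this place would move the number beyond the scatter stays open.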